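Methoxy to methyl on the aryl group of compound 2

The source may report more compounds than this note shows. Statements on the series, on what has been measured and on what is new or still open speak of the compounds shown alone.

Among the measured compounds shown here, in an assay on HEK293 cells for displacement of a labelled ligand from corticotropin-releasing factor receptor 1 (Homo sapiens) (on this read-out higher numbers stand for weaker inhibition and lower numbers for stronger inhibition), compound 2 `CCCCN(CCCC)c1cc(C)nc2c(-c3ccc(OC)cc3Cl)nn(C)c12` gives 4.8 nM, the higher of the two numbers measured so far; compound 1 `CCCCN(CCCC)c1cc(C)nc2c(-c3ccc(Cl)cc3Cl)nn(C)c12` gives 0.62 nM. For the measured compounds named here, the one measured step, a 7.7-fold higher number from compound 1 to compound 2 (0.89 log units; beyond the scatter), put methoxy in place of chloro on that carbon. Compound 3 `CCCCN(CCCC)c1cc(C)nc2c(-c3ccc(C)cc3Cl)nn(C)c12` carries methyl in place of methoxy on an aromatic carbon. Methyl, like chloro, brings no hydrogen-bond acceptor, so part of that step is expected to reverse, because compound 1 gives 0.62 nM. The expected step is a 3.2-fold lower number from compound 2 to compound 3 (0.51 log units; beyond the scatter), smaller than the measured one. Compound 3 is estimated at 1.5 nM, within 0.5 nM to 4.5 nM.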

Compound 3, inhibition constant: 2.8 nM
Estimate against measurement, compound 3: 1.9-fold (0.27 log units) below, within the range that was stated.
By their numbers in this assay, from the lowest: compound 1; then compounds 3 and 2 (each within the scatter of the next).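

In this assay, methoxy and methyl on this aromatic carbon are not told apart, with a 1.7-fold lower number from compound 2 to compound 3 (0.23 log units; within the scatter) as the step between them. Chloro does stand apart from methyl, with a 4.5-fold higher number from compound 1 to compound 3 (0.65 log units; beyond the scatter) as the step, so losing the hydrogen-bond acceptor of methoxy does not by itself reach the number of compound 1. No measurement bears on the cause of either step.

Open, on these data alone, is how fluoro, trifluoromethyl or an amine on this carbon would read against compound 1. Also open, as far as these compounds go, is whether the gap between chloro and methyl holds on other cores.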